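Replacing a chlorophenyl group with a cyanophenyl group

The source may hold more compounds than are shown below. What is called first, only, known or untested is meant among the compounds shown, and "the series" means these compounds.

Compound 1 `N#CCNC(=O)c1ccc(NCc2cncn2Cc2ccc(C#N)cc2)cc1-c1ccccc1` was tested in a functional assay on NIH3T3 cells (Mus musculus); a higher number here means that more compound is needed for the effect, a lower number that less compound is needed. In this assay compound 1 gives only a limit of > 10 uM. Compound 2 `CSCC[C@H](NC(=O)c1ccc(NCc2cncn2Cc2cccc(Cl)c2)cc1-c1ccccc1)C(=O)O` likewise reaches only a limit of > 10 uM in this assay. Compound 3 `COC(=O)[C@H](CCSC)NC(=O)c1ccc(NCc2cncn2Cc2cccc(Cl)c2)cc1-c1ccccc1` also stops at a limit of > 10 uM in this assay. The step from compound 2 to compound 3, in which a step that the two limits leave unreadable from compound 2 to compound 3, therefore has no readable size. Compound 2 thus stands at a limit and not at a number, as do the two other values shown, because of the limit of > 10 uM in this assay, at which 3 of the 3 values shown sit.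

Compound 4 `CSCC[C@H](NC(=O)c1ccc(NCc2cncn2Cc2ccccc2C#N)cc1-c1ccccc1)C(=O)O` differs from compound 2 in one place: 2-cyanophenyl in place of 3-chlorophenyl on a saturated chain carbon bound to an aromatic nitrogen. Going by the values given here, no measured step bears on this change in a readable way, since every step available sits at the limit. For compound 4 the value in this assay is expected at 15 uM, with a range from 5 uM to 50 uM. The expected step that the limit leaves unreadable from compound 2 to compound 4 is accordingly small and most likely hidden at the limit again.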

Compound 4, concentration for half-maximal effect: > 10 uM
Compound 4: a limit, no number; the forecaster's own chance of this, stated with the estimate: 80%; the middle value does not contradict the limit.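

Compound 4 also gives only a limit, so the step between compound 2 and compound 4 cannot be read, because no compound here yields a number: the limit of > 10 uM in this assay, at which 4 of the 4 values shown sit.

The compounds shown leave open how far 2-cyanobenzyl in place of 3-chlorobenzyl, or any other single change, shifts the concentration needed for the effect.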